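The compounds below may be only part of what the source reports. "The series", "measured", "known", "first", "only" and "open" are said of these compounds alone.

Compound 1, `O=C(Nc1ccc(F)cc1)N1N=C(c2ccccc2)CC1c1ccc(F)cc1`: 25 nM
Compound 2, `CC1=NN(C(=O)Nc2ccc(F)cc2)C(c2ccc(F)cc2)C1`: 900 nM

For the measured compounds named here, in an assay on HEK293 cells for inhibition of Voltage-dependent T-type calcium channel subunit alpha-1H (Homo sapiens), read by FLIPR and calcium flux, with a stated time of 3 min (on this read-out lower numbers stand for stronger inhibition and higher numbers for weaker inhibition), compound 2 has the highest of the two numbers; the only measured step leading to it, a 36-fold higher number from compound 1 to compound 2 (1.56 log units; beyond the scatter), came from putting methyl in place of phenyl on a carbon with a double bond to nitrogen, and it was large.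

Compound 3 `O=C(Nc1ccc(F)cc1)N1N=C(c2cc[n+]([O-])cc2)CC1c1ccc(F)cc1` differs from compound 2 by a group of 7 heavy atoms (5 carbon, 1 nitrogen, 1 oxygen; one six-membered aromatic ring with 1 hetero atom) in place of one carbon atom, on a carbon with a double bond to nitrogen. A six-membered aromatic ring thus returns to the position where compound 1 carries phenyl, so the step from compound 1 to compound 2 is the one that bears on this change, and it is expected to be largely reversed. The entering ring is not phenyl, however, so a full return to the number of compound 1 is not assumed; the expected step is a 15-fold lower number from compound 2 to compound 3 (1.18 log units; beyond the scatter).

Compound 3 is therefore estimated at 60 nM, with a range from 15 nM to 250 nM.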

Compound 3, half-maximal inhibitory concentration: 110 nM
For compound 3 the middle estimate is 1.8-fold (0.26 log units) below the measured one, and the stated range covers the measured number.
By their numbers in this assay, from the lowest: compound 1; then compound 3; then compound 2.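

In this assay methyl is not the only replacement that can be improved on at this position, and phenyl is not the only ring that works: the group of 7 heavy atoms, a six-membered aromatic ring with 1 hetero atom, gives an 8.2-fold lower number from compound 2 to compound 3 (0.91 log units; beyond the scatter) and so wins back part of the loss seen with methyl. The recovery is only partial, since the same ring in place of phenyl gives a 4.4-fold higher number from compound 1 to compound 3 (0.64 log units; beyond the scatter) in the same read-out, which shows that this position tells apart two six-membered aromatic rings and not just a ring from methyl. Nothing available here gives a reason for either step.

Still open, as far as these compounds go, is whether an aromatic ring is needed at all, which a cyclohexyl group or a longer chain such as butyl would test. Also open, from the compounds shown here alone, is whether plain pyridine, without the oxygen, or a phenyl ring bearing an amine would give a number closer to that of compound 1 or of compound 3.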